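Aryl sulfamate amides: one amino substituent exchanged

A few compounds are considered here, and "the series" means these few. Any claim that something is new, unique, unknown or untested is made for them only; others in the source may bear on it.

Measured so far:
compound 1, `NS(=O)(=O)Oc1ccc2c(c1)CN(C(=O)c1cccc(N(Cc3ccccc3)Cc3ccco3)c1)CC2`, in an assay on HEK293 cells for inhibition of Steryl-sulfatase (Homo sapiens), tested at 0.1 uM (on this read-out lower numbers stand for a weaker effect and higher numbers for a stronger effect at the one concentration tested), compound 1 gives 27.5%
compound 2, `CCN(Cc1cccnc1)c1ccc(C(=O)N2CCc3ccc(OS(N)(=O)=O)cc3C2)cc1`, in this assay compound 2 gives 35.7%

Compound 2 stands highest of the two numbers available, but its nearest neighbour, compound 1, lies only a few points lower, a gap within the scatter, so no order between the two can be claimed. Among the compounds with values here, the two measured compounds differ in more than one place, and no single step between them is therefore recorded.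

Compound 3, `CN(CCN1CCCCC1)c1ccc(C(=O)N2CCc3ccc(OS(N)(=O)=O)cc3C2)cc1`, differs from compound 2 in one place: methyl(2-(piperidin-1-yl)ethyl)amino in place of ethyl((pyridin-3-yl)methyl)amino on an aromatic carbon. Within the data shown here, with no measured step of this kind to rest on, the expected change from compound 2 to compound 3 is none beyond the scatter, and the estimated step is a number 3.7 percentage points lower from compound 2 to compound 3 (within the scatter). Compound 3 is expected to give about 32% in this assay, with a range from 10% to 55%.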

Compound 3, a percentage reported as inhibition, at one concentration (the size of the read-out at that concentration, not a potency): 0.3%
For compound 3 the middle estimate is 31.7 percentage points above the measured one; measured number below the stated range.
By their numbers in this assay, from the lowest: compound 3; then compounds 1 and 2 (each within the scatter of the next).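

Within the data shown here, exchanging ethyl((pyridin-3-yl)methyl)amino for methyl(2-(piperidin-1-yl)ethyl)amino on this aromatic carbon, para to a large group, gives a number 35.4 percentage points lower from compound 2 to compound 3 (beyond the scatter) in this assay, the first reading of a single change. The position therefore does not accept every amino substituent alike. The two groups have the same counts of heavy atoms, hydrogen-bond donors and acceptors, and neither carries a net charge, but the six-membered aromatic ring with 1 hetero atom gives way to a six-membered non-aromatic ring with 1 hetero atom. No available measurement explains the size of this step. Going by these compounds, the exchange alters the ring, the chain and the small alkyl group together, so which of these carries the step remains open. On these data alone, whether a morpholine ring on the same ethyl chain, or a phenyl ring in place of the pyridine, would keep the read-out also remains open.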